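A few compounds are considered here, and "the series" means these few. Any claim that something is new, unique, unknown or untested is made for them only; others in the source may bear on it.

Measured in an ADME assay on MT4 cells (Homo sapiens) for cytotoxicity, read by MTT assay, with a stated time of 5 days; on this read-out lower numbers stand for higher toxicity in this test and higher numbers for lower toxicity in this test:
- compound 1 `CNc1cc(Oc2c(OC)cc3cc(C#N)ccc3c2OC)nc(Nc2ccc(C#N)cc2)n1`: 239000 nM
- compound 2 `CCNc1cc(Oc2c(OC)cc3cc(C#N)ccc3c2OC)nc(Nc2ccc(C#N)cc2)n1`: > 125000 nM, a limit
- compound 3 `COc1cc2cc(C#N)ccc2c(OC)c1Oc1cc(NC2CCOCC2)nc(Nc2ccc(C#N)cc2)n1`: > 125000 nM, a limit

Compound 3 gives only a limit, > 125000 nM. Most of the set sits at the limit of > 125000 nM in this assay, at which 2 of the 3 values shown sit. Compound 1 alone carries a number, and it does not fall under that limit.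

Compound 4 `COc1cc2cc(C#N)ccc2c(OC)c1Oc1cc(NCC(O)CO)nc(Nc2ccc(C#N)cc2)n1` differs from compound 3 by 2,3-dihydroxypropyl in place of oxan-4-yl on a nitrogen on an aromatic ring.

The measured steps that bear on this change are the other swaps at the same nitrogen: a step that the limit leaves unreadable from compound 1 to compound 2, a step that the limit leaves unreadable from compound 1 to compound 3 and a step that the two limits leave unreadable from compound 2 to compound 3. None of them gives a size. Methyl, ethyl and oxan-4-yl on that nitrogen all leave the readings in the same high region of this assay, so no step beyond the scatter is expected, and no direction can be assigned. For the measured compounds named here, the only anchor for a number is compound 1 at 239000 nM.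

The expected change is a step that the limit leaves unreadable from compound 3 to compound 4. A report of a limit alone would be no surprise here. The estimated value for compound 4 is 200000 nM, with an expected range of 100000 nM to 400000 nM.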

Compound 4, half-maximal cytotoxic concentration: 29500 nM
The estimate for compound 4 lay 6.8-fold (0.83 log units) above the measured number; the measured number lies below the stated range.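

In this assay, the nitrogen on an aromatic ring now proves able to move this read-out: 2,3-dihydroxypropyl gives an at least 4.2-fold lower number from compound 3 to compound 4 (0.62 log units; beyond the scatter), and the same chain gives an at least 4.2-fold lower number from compound 2 to compound 4 (0.62 log units; beyond the scatter) and an 8.1-fold lower number from compound 1 to compound 4 (0.91 log units; beyond the scatter). For the compounds shown here, the steps among methyl, ethyl and oxan-4-yl on that nitrogen cannot be read, so compound 4 supplies the first sized change at this position, in the direction of higher toxicity in this test, and ethyl in compound 2 shows that an open chain there does not by itself go with a lower number. Only the step from compound 1 joins two numbers, while the other two rest on limits: the limit of > 125000 nM in this assay, at which 2 of the 4 values shown sit.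

Going by these compounds alone, compound 4 is the single example of a hydroxyl-bearing chain here, so it remains open whether the lower number belongs to the hydroxyl groups, to one of them, or to this particular chain. A 2-hydroxyethyl or 2-methoxyethyl chain would separate these readings, and a 2-aminoethyl chain or a carboxylic acid on the same nitrogen would show whether the change extends beyond hydroxyl groups.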